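Replacing the indolyl group in compound 2

The source may report more compounds than this note shows. Statements on the series, on what has been measured and on what is new or still open speak of the compounds shown alone.

In a functional assay on DU-145 cells (Homo sapiens) for inhibition, read by trypan blue exclusion, with a stated time of 96 h (a higher number here means a weaker inhibitor of growth, a lower number a stronger inhibitor of growth), compound 2 `Cc1ccc(S/C(=C/c2c[nH]c3ccccc23)C(=O)c2ccc(Cl)cc2)cc1` gives 10000 nM, the higher of the two numbers, and compound 1 `COc1ccccc1/C=C(/SCc1ccc(Cl)cc1)C(=O)c1ccc(Cl)cc1` gives 1000 nM. That gap lies beyond the scatter. Compound 3 `COc1ccccc1/C=C(/Sc1ccc(C)cc1)C(=O)c1ccc(Cl)cc1` differs from compound 2 as follows: 2-methoxyphenyl in place of 1H-indol-3-yl on a double-bonded chain carbon bound to a double-bonded chain carbon. Among the measured compounds shown here, no measured single-site step is available as a guide. The 2-methoxyphenyl group also occurs in compound 1 at 1000 nM, although that compound differs from compound 3 elsewhere, so a lower number beyond the scatter is expected. The expected change is a 5.0-fold lower number from compound 2 to compound 3 (0.70 log units; beyond the scatter). For compound 3 the estimated value is 2000 nM, with an expected range of 500 nM to 7000 nM.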

Compound 3, concentration for 50% growth inhibition: 25000 nM
For compound 3 the middle estimate is 13-fold (1.10 log units) below the measured one, outside the stated range (above it).
By their numbers in this assay, from the lowest: compound 1; then compound 2; then compound 3.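

In this assay 2-methoxyphenyl in place of 1H-indol-3-yl on a double-bonded chain carbon gives a 2.5-fold higher number from compound 2 to compound 3 (0.40 log units; beyond the scatter) and so brings no gain while 4-methylphenyl sits on the sulfur. 4-methylphenyl in place of 4-chlorobenzyl on a sulfur gives a 25-fold higher number from compound 1 to compound 3 (1.40 log units; beyond the scatter) as the large step, so the low number of compound 1 goes with its 4-chlorobenzyl group and not with 2-methoxyphenyl alone. Nothing available explains either step.

Open, going by these compounds, is how 1H-indol-3-yl reads with 4-chlorobenzyl on the sulfur. Also open, on these data alone, is whether an unsubstituted benzyl or a longer chain on the sulfur would keep the low number.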